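Switching a benzyl group for a methoxyphenoxy group

The source may hold more compounds than are shown below. What is called first, only, known or untested is meant among the compounds shown, and "the series" means these compounds.

The three measured compounds in an ADME assay on HepG2 cells (Homo sapiens) for cytotoxicity, read by luminescence, CellTiter-Glo and ATP content, with a stated time of 72 h (a higher number here means that more compound is needed for the effect, a lower number that less compound is needed), are these:
Compound 1, `FC(F)(F)c1ccc(-c2ccc3c(NCCCNCc4ccco4)ccnc3c2)cc1`, gives 3470 nM.
Compound 2, `Fc1ccc(Oc2ccc3c(NCCCNCc4ccco4)ccnc3c2)cc1`, gives 16000 nM.
Compound 3, `Fc1ccc(Cc2ccc3c(NCCCNCc4ccco4)ccnc3c2)c(Cl)c1`, gives 5730 nM.

Compound 3 stands second highest of the three numbers. Its nearest neighbour is compound 1, and the step of a 1.7-fold higher number from compound 1 to compound 3 (0.22 log units; within the scatter) lies within the scatter, so those two cannot be told apart. Going by the values given here, the step of a 2.8-fold lower number from compound 2 to compound 3 (0.45 log units; beyond the scatter) lies beyond the scatter, and it is the one comparison that sets compound 3 apart from another compound.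

Compound 4 is `COc1ccc(Oc2ccc3c(NCCCNCc4ccco4)ccnc3c2)cc1`. Relative to compound 3 the change is 4-methoxyphenoxy in place of 2-chloro-4-fluorobenzyl on an aromatic carbon. Among the compounds with values here, two measured steps bear on this. The step of a 2.8-fold lower number from compound 2 to compound 3 (0.45 log units; beyond the scatter) shows that exchanging a phenoxy group for a benzyl group lowered the number; compound 4 reverses that exchange. Within the data shown here, the step of a 4.6-fold higher number from compound 1 to compound 2 (0.66 log units; beyond the scatter) shows the only phenoxy compound giving the highest number of the set. Among the measured compounds shown here, the phenoxy group of compound 2 carries a fluorine and that of compound 4 a methoxy group, a difference no measured step covers, so the expectation rests on the phenoxy-versus-benzyl comparison alone. For compound 4 a modest rise is expected, a 2.3-fold higher number from compound 3 to compound 4 (0.36 log units; beyond the scatter). The estimate for compound 4 is 13000 nM, with a range from 5000 nM to 35000 nM.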

Compound 4, half-maximal effective concentration: 5300 nM
Compound 4: the middle estimate sits 2.5-fold (0.39 log units) above what was measured; the measured number falls inside the stated range.
By their numbers in this assay, from the lowest: compounds 1, 4 and 3 (each within the scatter of the next); then compound 2.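

At this position, a phenoxy group does not by itself give a high number in this assay. Compound 4 cannot be told apart from the two compounds without a phenoxy group: the step for 4-methoxyphenoxy in place of 2-chloro-4-fluorobenzyl is a 1.1-fold lower number from compound 3 to compound 4 (0.03 log units; within the scatter), and the step for 4-methoxyphenoxy in place of 4-(trifluoromethyl)phenyl is a 1.5-fold higher number from compound 1 to compound 4 (0.18 log units; within the scatter). Going by these compounds alone, what the earlier compounds could not show is that the group carried on the phenoxy ring can matter: methoxy in place of fluoro gives a 3.0-fold lower number from compound 2 to compound 4 (0.48 log units; beyond the scatter), so the high number of compound 2 cannot be read as a mark of phenoxy groups in general. No measurement here explains why these groups compare as they do.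

As far as these compounds go, whether this difference between methoxy and fluoro carries over to other groups on the phenoxy ring, such as a dimethylamino group or a carboxylic acid, remains open. Also open, from the compounds shown here alone, is whether a benzyl ring with a methoxy group would match compound 4, which would separate the effect of the linking atom from that of the group on the ring.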